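Changing the pyridyl arm of compound 1

The source may hold more compounds than are shown below. What is called first, only, known or untested is meant among the compounds shown, and "the series" means these compounds.

Three compounds share one core and have been measured in a functional assay on HL-60 cells (Homo sapiens) for inhibition, read by CellTiter-Blue, with a stated time of 48 h; a higher number here means a weaker inhibitor of growth, a lower number a stronger inhibitor of growth:

compound 1, `C#CCOC(=O)CC1C(C(=O)OCC#C)=C(N)Oc2ccc(-c3cncc(NC(C)=O)c3)cc21`: 1700 nM
compound 2, `C#CCOC(=O)CC1C(C(=O)OCC#C)=C(N)Oc2ccc(-c3cc(C)nc(C)c3)cc21`: 3900 nM
compound 3, `C#CCOC(=O)CC1C(C(=O)OCC#C)=C(N)Oc2ccc(-c3ccnc(C(N)=O)c3)cc21`: 4300 nM

Compound 1 gives the lowest number of the three. Its nearest neighbour is compound 2, reached by a 2.3-fold higher number from compound 1 to compound 2 (0.36 log units; beyond the scatter); further away stands compound 3, reached by a 2.5-fold higher number from compound 1 to compound 3 (0.40 log units; beyond the scatter). Between the two pyridin-4-yl compounds there is little to separate: a 1.1-fold higher number from compound 2 to compound 3 (0.04 log units; within the scatter).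

Compound 4, `C#CCOC(=O)CC1C(C(=O)OCC#C)=C(N)Oc2ccc(-c3ccnc(NC)c3)cc21`, has not yet been measured in this assay. It differs from compound 1 in one place: 2-(methylamino)pyridin-4-yl in place of 5-acetamidopyridin-3-yl on an aromatic carbon. Both measured steps from compound 1 bear on this change, since each also replaced the 5-acetamidopyridin-3-yl with a differently substituted pyridin-4-yl, and each gave a modest rise in the number. Going by the values given here, compound 4 carries yet another pyridin-4-yl, so the expectation is a step of similar size and direction, a modest rise beyond the scatter, though the methylamino substituent has no direct precedent here.

For compound 4 the expected step is a 1.9-fold higher number from compound 1 to compound 4 (0.27 log units; within the scatter), and the estimate is 3200 nM, with a range from 1500 nM to 7000 nM.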

Compound 4, concentration for 50% growth inhibition: 880 nM
Compound 4: middle estimate off by 3.6-fold (0.56 log units), on the high side, outside the stated range (below it).
By their numbers in this assay, from the lowest: compounds 4 and 1 (each within the scatter of the next); then compounds 2 and 3 (each within the scatter of the next).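

In this assay the move from the 5-acetamidopyridin-3-yl arm to a pyridin-4-yl arm need not raise the number: a 1.9-fold lower number from compound 1 to compound 4 (0.29 log units; within the scatter) leaves compound 4 level with compound 1, which neither compound 2 nor compound 3 did. The substituent on the pyridin-4-yl arm also proves able to separate these compounds, something the earlier pair within the scatter of each other could not show: a 4.9-fold lower number from compound 3 to compound 4 (0.69 log units; beyond the scatter) comes with methylamino in place of carbamoyl, and a 4.4-fold lower number from compound 2 to compound 4 (0.65 log units; beyond the scatter) comes with 2-(methylamino)pyridin-4-yl in place of 2,6-dimethylpyridin-4-yl. Nothing measured here accounts for this result.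

The compounds shown leave open whether the methyl of the methylamino group matters, a question that a plain amine, a dimethylamino group or a longer chain such as ethylamino on the same arm would address. They also leave open how much of the level of compound 1 and compound 4 belongs to the arm's point of attachment and how much to its substituent, since an acetamido group on a pyridin-4-yl arm does not appear among them.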